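Changing the amide group of compound 3 to isopropyl

The source may hold more compounds than are shown below. What is called first, only, known or untested is meant among the compounds shown, and "the series" means these compounds.

compound 1 `COc1ccc(/C=C/c2cc(OC)cc(OC)c2/C=C/C(=O)NC2CC2)cc1` gives 10200 nM
compound 2 `CCCCCCCCNC(=O)/C=C/c1c(/C=C/c2ccc(OC)cc2)cc(OC)cc1OC` gives 8060 nM
compound 3 `COc1ccc(/C=C/c2cc(OC)cc(OC)c2/C=C/C(=O)Nc2cc(OC)c(OC)c(OC)c2)cc1` gives 8150 nM

In a functional assay on B16-F10 cells (Mus musculus) for inhibition, read by MTT assay, with a stated time of 48 h (a higher number here means a weaker inhibitor, a lower number a stronger inhibitor), compound 3 stands at 8150 nM and all three compounds lie within the scatter of one another. Compound 4 `COc1ccc(/C=C/c2cc(OC)cc(OC)c2/C=C/C(=O)NC(C)C)cc1` keeps the shared core and carries isopropyl in place of 3,4,5-trimethoxyphenyl on an amide-type nitrogen.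

Three measured steps at this same nitrogen bear on the change: a 1.3-fold lower number from compound 1 to compound 2 (0.10 log units; within the scatter) for octyl in place of cyclopropyl, a 1.3-fold lower number from compound 1 to compound 3 (0.10 log units; within the scatter) for 3,4,5-trimethoxyphenyl in place of cyclopropyl, and a 1.0-fold higher number from compound 2 to compound 3 (0.00 log units; within the scatter) for 3,4,5-trimethoxyphenyl in place of octyl. Each stays within the scatter, with the cyclopropyl of compound 1 at 10200 nM as the closest guide to isopropyl. No step beyond the scatter is therefore expected, and the estimated step is a 1.2-fold higher number from compound 3 to compound 4 (0.07 log units; within the scatter) in either direction of little weight. Compound 4 is expected at 9500 nM (estimated range 5000 nM to 18000 nM).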

Compound 4, half-maximal inhibitory concentration: 4020 nM
Estimate against measurement, compound 4: 2.4-fold (0.37 log units) above; measured number below the stated range.
By their numbers in this assay, from the lowest: compounds 4, 2, 3 and 1 (each within the scatter of the next, the first and the last beyond it).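

In this assay, among the compounds shown here, isopropyl gives the first steps beyond the scatter at this amide-type nitrogen (a 2.0-fold lower number from compound 3 to compound 4 (0.31 log units; beyond the scatter)) and (a 2.5-fold lower number from compound 1 to compound 4 (0.40 log units; beyond the scatter)), both modest, so the substituent there is not as indifferent as the earlier compounds suggested. Compound 2 goes against any clean separation of isopropyl from the other groups, since its octyl remains within the scatter (a 2.0-fold lower number from compound 2 to compound 4 (0.30 log units; within the scatter)). Nothing available explains why isopropyl stands apart from 3,4,5-trimethoxyphenyl and cyclopropyl.

The compounds shown leave open whether ethyl, tert-butyl or a shorter straight chain such as propyl would match isopropyl on this nitrogen. They also leave open whether the amide hydrogen matters, which a dimethyl amide would test.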